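Moving the Sulfur Ring's Attachment Point on the Shared Core

The source may hold more compounds than are shown below. What is called first, only, known or untested is meant among the compounds shown, and "the series" means these compounds.

Measured so far:
- compound 1, `CCCOC(=O)C1=C(C)NC(=O)NC1c1ccco1`: 3%
- compound 2, `CCCOC(=O)C1=C(C)NC(=O)NC1c1cccs1`: 32%

Both compounds were tested in an assay on membranes from HeLa cells for displacement of a labelled ligand from adenosine receptor A3 (Homo sapiens), read by scintillation counting, with a stated time of 180 min, tested at 1 uM; a higher number here means more inhibition at the concentration tested (going by the name of the read-out), a lower number less inhibition. Compound 1 gives 3% and compound 2 gives 32%. Within the data shown here, of these two numbers, compound 2 stands highest, and its only neighbour, compound 1, lies lower by the step of a number 29 percentage points higher from compound 1 to compound 2 (beyond the scatter), which comes from putting thiophen-2-yl in place of furan-2-yl on a saturated ring carbon.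

The next compound, compound 3, `CCCOC(=O)C1=C(C)NC(=O)NC1c1ccsc1`, differs from compound 2 by thiophen-3-yl in place of thiophen-2-yl on a saturated ring carbon. Among the measured compounds shown here, no measured step here changes the attachment point of a ring in this way; the one step known, from compound 1 to compound 2, exchanges one ring for another and is therefore only a loose guide. It shows that the group on this saturated ring carbon can shift the read-out by a modest amount, but gives no direction for the present change. The step from compound 2 to compound 3 is therefore expected to be small, a number 6 percentage points lower from compound 2 to compound 3 (within the scatter), within or near the scatter. Compound 3 is estimated to give 26% in this assay, with a likely range from 5% to 50%.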

Compound 3, a percentage reported as inhibition, at one concentration (the size of the read-out at that concentration, not a potency): 6%
Estimate against measurement, compound 3: 20 percentage points above; measured number inside the range.
By their numbers in this assay, from the lowest: compounds 1 and 3 (each within the scatter of the next); then compound 2.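

The step of a number 26 percentage points lower from compound 2 to compound 3 (beyond the scatter) comes from thiophen-3-yl in place of thiophen-2-yl in this assay, so with the same atoms joined differently, the attachment point of the ring alone can move this read-out beyond the scatter. The step of a number 3 percentage points higher from compound 1 to compound 3 (within the scatter) comes from thiophen-3-yl in place of furan-2-yl, which shows that a sulfur ring at this position does not by itself set compound 2 apart from compound 1, and among these three compounds only thiophen-2-yl gives a number beyond the scatter of the others. No measurement available here accounts for this difference between the two attachment points.

On these data alone, it remains open whether furan-3-yl, or a phenyl ring, on the same saturated ring carbon would fall with thiophen-2-yl or with the other two groups. As far as these compounds go, it is equally open whether the gap between the two thiophene attachment points would persist if the propoxycarbonyl group gave way to a longer chain such as butoxycarbonyl, or to a carboxylic acid.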